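Replacing a side chain on compound 1

A few compounds are considered here, and "the series" means these few. Any claim that something is new, unique, unknown or untested is made for them only; others in the source may bear on it.

compound 1 `Cn1ncc(Cl)c1-c1cc(C(=O)N[C@@H]2CN[C@H](CCNS(C)(=O)=O)C[C@H]2c2ccc(F)c(F)c2)oc1Cl` at 1530 nM
compound 2 `Cn1ncc(Cl)c1-c1cc(C(=O)N[C@@H]2CN[C@H](CCn3cncn3)C[C@H]2c2ccc(Cl)c(Cl)c2)oc1Cl` at 1560 nM

Both values come from a functional assay on OVCAR-8 cells (Homo sapiens) for antiproliferative activity (a lower number here means a stronger inhibitor, a higher number a weaker inhibitor), and lie within the usual scatter of each other, so compound 1 stands level with compound 2. Compound 3 `CNC(=O)C[C@@H]1C[C@@H](c2ccc(F)c(F)c2)[C@H](NC(=O)c2cc(-c3c(Cl)cnn3C)c(Cl)o2)CN1` has methylcarbamoyl in place of (methanesulfonamido)methyl on a saturated chain carbon bound to a saturated ring carbon and otherwise matches compound 1. Within the data shown here, no measured pair shows this change alone. The expectation therefore starts from compound 1 at 1530 nM as its anchor. The estimated step of a 1.2-fold lower number from compound 1 to compound 3 (0.07 log units; within the scatter) in this assay is expected to stay within the scatter, with no firm direction. Compound 3 is expected at 1300 nM with 450 nM to 3800 nM as the estimated range.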

Compound 3, half-maximal inhibitory concentration: 800 nM
Beside the measured number, compound 3's estimate is 1.6-fold (0.21 log units) above it; low and high end bracket the measured number.
By their numbers in this assay, from the lowest: compounds 3, 1 and 2 (each within the scatter of the next).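

In this assay, among these compounds, the first comparison that changes only this position puts methylcarbamoyl in place of (methanesulfonamido)methyl, and the result is a 1.9-fold lower number from compound 1 to compound 3 (0.28 log units; within the scatter). On this saturated chain carbon, bound to a saturated ring carbon, the group with 6 heavy atoms can thus give way to the one with 4 while the number stays within the scatter. No measurement here offers an explanation for this step. Going by these compounds, whether a carboxylic acid or an amine at the same place would keep the number in this range remains open.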